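Phenyl to 4-fluorophenyl: expected cytotoxicity of compound 3

A few compounds are considered here, and "the series" means these few. Any claim that something is new, unique, unknown or untested is made for them only; others in the source may bear on it.

Among the compounds with values here, compound 2 `COc1ccc(-c2cc(-c3ccc4cc(F)ccc4n3)n(-c3ccccc3)n2)cc1` gives, in an ADME assay on Huh-7 cells (Homo sapiens) for cytotoxicity, read by XTT assay, with a stated time of 3 days, tested at 20 uM (on this read-out higher numbers stand for a weaker effect at the one concentration tested and lower numbers for a stronger effect), 104%, the highest of the two numbers measured so far; its only neighbour is compound 1 `Fc1ccc(-c2cc(-c3ccc4cc(F)ccc4n3)n(-c3ccccc3)n2)cc1`, which in this assay gives 88.1%. Within the data shown here, the single measured step, a number 15.9 percentage points higher from compound 1 to compound 2 (beyond the scatter), concerns methoxy in place of fluoro on an aromatic carbon and lies beyond the scatter.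

Compound 3 `COc1ccc(-c2cc(-c3ccc4cc(F)ccc4n3)n(-c3ccc(F)cc3)n2)cc1` differs from compound 2 by fluoro in place of hydrogen on an aromatic carbon, on an aromatic carbon of a six-membered aromatic ring of carbon only. Among the measured compounds shown here, no measured step touches this position: the step from compound 1 to compound 2 changes a different group elsewhere in the molecule and gives no guide to size or direction here. With nothing to anchor a shift, the expected step of a number 5 percentage points lower from compound 2 to compound 3 (within the scatter) is kept within the scatter, in no particular direction. Compound 3 is therefore estimated at 99%, with a range from 84% to 112%.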

Compound 3, a percentage reported as activity, at one concentration (the size of the read-out at that concentration, not a potency): 98.8%
Compound 3: middle estimate off by 0.2 percentage points, on the high side, within the range that was stated.
By their numbers in this assay, from the lowest: compound 1; then compounds 3 and 2 (each within the scatter of the next).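

In this assay, within the data shown here, the change from phenyl to 4-fluorophenyl gives a number 5.2 percentage points lower from compound 2 to compound 3 (within the scatter), the first measured step at this position. Fluoro in place of hydrogen, para to a large group, therefore stays within the usual scatter on this read-out, whereas the methoxy in place of fluoro change elsewhere in the molecule gives a number 15.9 percentage points higher from compound 1 to compound 2 (beyond the scatter), which is beyond it. No available evidence bears on the reason for this outcome.

As far as these compounds go, it remains open whether a group other than fluoro at this place, such as an amine, a carboxylic acid or a longer chain, would also stay within the scatter. From the compounds shown here alone, it is also open whether fluoro in place of hydrogen at this position would read the same on compound 1.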